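A few compounds are considered here, and "the series" means these few. Any claim that something is new, unique, unknown or untested is made for them only; others in the source may bear on it.

Of the compounds shown here, two have been read so far in an ADME assay on L02 cells (Homo sapiens) for cytotoxicity, read by MTT assay, with a stated time of 24 h; a higher number here means a weaker inhibitor, a lower number a stronger inhibitor. Compound 1 (`CN1C/C(=C\c2ccc(C(C)(C)C)cc2)C(=O)/C(=C/c2ccccc2F)C1`) gives 25800 nM and compound 2 (`COc1cc(/C=C2\CN(C)C/C(=C\c3ccc(Cl)cc3)C2=O)cc(OC)c1`) gives 18900 nM, so compound 2 stands within the usual scatter of compound 1. Compound 3 (`COc1cc(/C=C2\CN(C)C/C(=C\c3cccc([N+](=O)[O-])c3)C2=O)cc(OC)c1`) has not yet been measured. It carries 3-nitrophenyl in place of 4-chlorophenyl on a double-bonded chain carbon bound to a double-bonded ring carbon. Among the measured compounds shown here, no single-place step between measured compounds is available to size this change, and the data give no direction for it. With only these two close values to go on, no change beyond the scatter is expected, and the estimated step, a 1.1-fold lower number from compound 2 to compound 3 (0.05 log units; within the scatter), is correspondingly small. For compound 3 the expected value in this assay is 17000 nM, with an estimated range of 7000 nM to 38000 nM.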

Compound 3, half-maximal inhibitory concentration: 10800 nM
Compound 3: middle estimate off by 1.6-fold (0.20 log units), on the high side; the range from low to high includes it.
By their numbers in this assay, from the lowest: compounds 3, 2 and 1 (each within the scatter of the next, the first and the last beyond it).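

In this assay, the piece now has its first single-place step: 3-nitrophenyl in place of 4-chlorophenyl on a double-bonded chain carbon bound to a double-bonded ring carbon gives a 1.8-fold lower number from compound 2 to compound 3 (0.24 log units; within the scatter) and so stays within the scatter. This position therefore accepts a group with 2 hydrogen-bond acceptors in place of one with 0, with no change that can be told apart from repeat measurements. No measurement here bears on why the step has this size.

As far as these compounds go, it remains open whether an amine or a carboxylic acid on the phenyl ring at this place would move the number beyond the scatter. A single pair also cannot show whether the same exchange gives a similar step when the group on the other side of the shared core is different.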